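Cyclopentyl for isopropyl on sulfur: cytotoxicity notes

The source may report more compounds than this note shows. Statements on the series, on what has been measured and on what is new or still open speak of the compounds shown alone.

Measured compounds:
compound 1 `CCC(c1cc(O)nc(SC(C)C)n1)c1cccc2ccccc12` gives 16900 nM in a functional assay on MT4 cells (Homo sapiens) for cytotoxicity; on this read-out higher numbers stand for lower toxicity in this test and lower numbers for higher toxicity in this test
compound 2 `CCC(c1cc(O)nc(SC2CCCC2)n1)c1cccc2ccccc12` gives > 200000 nM in this assay; this value is a limit of the test, not a number.
compound 3 `CCC(c1cc(O)nc(SC(C)C)n1)c1c(F)cccc1F` gives 130000 nM in this assay

Compound 1 and compound 3 share the change examined here but carry different cores; the difference between the two cores is not broken down here. Compound 3 stands highest of the two numbers, with compound 1 the nearer one.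

The step from compound 1 to compound 2 is cyclopentyl in place of isopropyl on a sulfur. In this assay it gives an at least 11-fold higher number from compound 1 to compound 2 (1.07 log units; beyond the scatter). Its size is open at the top because of the limit of > 200000 nM in this assay, at which 1 of the 3 values shown sits.

Compound 4 `CCC(c1cc(O)nc(SC2CCCC2)n1)c1c(F)cccc1F` is not yet measured in this assay. The change from compound 3 to compound 4 is cyclopentyl in place of isopropyl on a sulfur, the same change as from compound 1 to compound 2, made on the same kind of place.

Since compound 3 already gives 130000 nM, and the same change moved compound 1 to compound 2 by an at least 11-fold higher number from compound 1 to compound 2 (1.07 log units; beyond the scatter), compound 4 is expected to give a higher number still; the step is estimated at a 2.3-fold higher number from compound 3 to compound 4 (0.36 log units; beyond the scatter). Compound 4 is thus expected at 300000 nM, within 150000 nM to 1000000 nM, most likely reported only as a limit.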

Compound 4, half-maximal cytotoxic concentration: > 200000 nM
Compound 4 was reported as a limit; the forecaster's own chance of this, stated with the estimate: 80%; the middle value does not contradict the limit.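

Working notes on carrying the change to a second core: on the core of compound 3, cyclopentyl in place of isopropyl on a sulfur gives, in this assay, an at least 1.5-fold higher number from compound 3 to compound 4 (0.18 log units; that floor lies within the scatter), so the printed floor alone does not establish a change on this core beyond the usual scatter. The two steps are compatible with the same direction on both cores, and both cyclopentyl compounds are reported only as a limit of the test rather than as a number: the limit of > 200000 nM in this assay, at which 2 of the 4 values shown sit. This does not show that the size of the step carries over from the core of compound 1 to the core of compound 3, since only lower bounds are available for the two steps: the same change on two cores in this assay, an at least 11-fold higher number (1.07 log units; beyond the scatter) from compound 1 to compound 2 and an at least 1.5-fold higher number (0.18 log units; that floor lies within the scatter) from compound 3 to compound 4; the limit leaves it open whether they differ.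

The compounds shown leave open how high the number would lie for either cyclopentyl compound in a test that reaches beyond this limit, and whether the same change behaves alike on any further core. They also leave open what other groups on the sulfur would give on these two cores, for example a longer chain such as n-butyl, a cyclohexyl ring or a benzyl group.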